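The source may hold more compounds than are shown below. What is called first, only, known or untested is meant among the compounds shown, and "the series" means these compounds.

In an ADME assay on HEp-2 cells (Homo sapiens) for cytotoxicity, read by MTT assay, with a stated time of 72 h (on this read-out lower numbers stand for stronger inhibition and higher numbers for weaker inhibition), compound 2 (`COc1ccc(C2=C(c3cc(OC)c(OC)c(OC)c3)C(=O)CC2O)cc1`) gives > 100 ug/mL, which is a limit of the assay and not a number. Compound 1 (`COc1cc(C2=C(c3ccc(OCC(=O)O)cc3)C(O)CC2=O)cc(OC)c1OC`) gives > 100 ug/mL, also a limit. For the measured compounds named here, the series so far stands at the limit of > 100 ug/mL in this assay, at which 2 of the 2 values shown sit. Compound 2 therefore has no numerical position, only a limit.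

Compound 3 (`CCOC(=O)COc1ccc(C2=C(c3cc(OC)c(OC)c(OC)c3)C(=O)CC2O)cc1`) is the next structure to be read, and it differs from compound 2 by ethoxycarbonyl in place of hydrogen on a saturated chain carbon bound to an oxygen on an aromatic ring. The change is ethoxycarbonyl in place of hydrogen on a saturated chain carbon bound to an oxygen on an aromatic ring.

Going by the values given here, the only measured step at that place is a step that the two limits leave unreadable from compound 1 to compound 2, with hydrogen in place of carboxy on a saturated chain carbon bound to an oxygen on an aromatic ring. It offers no size to carry over to the new change. With only a step that the two limits leave unreadable from compound 1 to compound 2 to go on, the expected step is a number no higher from compound 2 to compound 3 (the limit leaves the size open), with no direction and nothing beyond the scatter expected in this assay. Compound 3 is estimated at 100 ug/mL, with an expected range from 40 ug/mL to 200 ug/mL.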

Compound 3, half-maximal inhibitory concentration: > 100 ug/mL
Compound 3 ended at the assay's limit (the forecaster's own chance of this, stated with the estimate: 75%); the middle value lies on the limit itself.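

In this assay compound 3 gives > 100 ug/mL, a limit of the assay and not a number. No step among compound 1, compound 2 and compound 3 can be read: the limit of > 100 ug/mL in this assay, at which 3 of the 3 values shown sit.

On these data alone, whether carboxy, hydrogen or ethoxycarbonyl on the saturated chain carbon bound to an oxygen on an aromatic ring makes any difference to the read-out stays open.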